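Halogenated Phenyl for Hydroxy-Methoxy: Expecting Compound 4

The compounds below may be only part of what the source reports. "The series", "measured", "known", "first", "only" and "open" are said of these compounds alone.

The three measured compounds and their results in an ADME assay on MRC5 cells (Homo sapiens) for cytotoxicity; a lower number here means a stronger inhibitor, a higher number a weaker inhibitor:
Compound 1, `COc1ccc(Cn2cc(CNC(=O)c3ccc([N+](=O)[O-])o3)nn2)cc1F`, gives 324000 nM.
Compound 2, `O=C(NCc1cn(Cc2ccc(C(F)(F)F)cc2)nn1)c1ccc([N+](=O)[O-])o1`, gives 321000 nM.
Compound 3, `COc1cc(Cn2cc(CNC(=O)c3ccc([N+](=O)[O-])o3)nn2)ccc1O`, gives 182000 nM.

Compound 3 gives a number that differs from those of compound 1 and compound 2 only within the scatter, so none of the three is set apart from the others in this assay. Within the data shown here, the single one-point step among them, a 1.8-fold lower number from compound 1 to compound 3 (0.25 log units; within the scatter), agrees with this. Compound 2 and compound 3 are not joined by a described step; their two values simply lie within the scatter of each other.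

Compound 4, `O=C(NCc1cn(Cc2ccc(F)c(Cl)c2)nn1)c1ccc([N+](=O)[O-])o1`, arises from compound 3 by 3-chloro-4-fluorophenyl in place of 4-hydroxy-3-methoxyphenyl on a saturated chain carbon bound to an aromatic nitrogen. The step of a 1.8-fold lower number from compound 1 to compound 3 (0.25 log units; within the scatter) bears on it most directly: it swapped the phenyl group at the same place and stayed within the scatter. Compound 2, with a trifluoromethyl-bearing phenyl at that place, gives a number near those of the others. A halogenated phenyl is therefore expected to leave the number roughly where it is, with the expected step of a 1.5-fold higher number from compound 3 to compound 4 (0.19 log units; within the scatter) not beyond the scatter. Compound 4 is estimated at 280000 nM, within 120000 nM to 650000 nM.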

Compound 4, half-maximal inhibitory concentration: 254000 nM
Estimate against measurement, compound 4: 1.1-fold (0.04 log units) above; low and high end bracket the measured number.
By their numbers in this assay, from the lowest: compounds 3, 4, 2 and 1 (each within the scatter of the next).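

In this assay, a 1.4-fold higher number from compound 3 to compound 4 (0.14 log units; within the scatter) shows that the hydrogen-bond donor and acceptors of 4-hydroxy-3-methoxyphenyl can be exchanged for a phenyl group that has none, on a saturated chain carbon bound to an aromatic nitrogen, without the number moving beyond the scatter. The other new step, a 1.3-fold lower number from compound 1 to compound 4 (0.11 log units; within the scatter), removes the methoxy group of 3-fluoro-4-methoxyphenyl in favour of 3-chloro-4-fluorophenyl and also stays within the scatter, so across these swaps the phenyl group's substituents have not set any compound apart. Nothing measured here explains why the number stays so level at this place.

Going by these compounds, all four compounds carry a substituted phenyl group at this place, so it remains open whether an amine, a carboxylic acid or a longer chain there would move the number beyond the scatter. The compounds shown also leave open whether any change to the shared core would do so.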